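Methoxy on the chain of compound 3

The compounds below may be only part of what the source reports. "The series", "measured", "known", "first", "only" and "open" are said of these compounds alone.

In a functional assay on KB cells (Homo sapiens) for inhibition (on this read-out higher numbers stand for weaker inhibition and lower numbers for stronger inhibition), the series holds compound 1 (`N#Cc1c(Br)n(COCc2ccccc2)c2ncnc(N)c12`), compound 2 (`NC(=O)c1c(N)n(COCc2ccccc2)c2ncnc(N)c12`) and compound 3 (`CCOCn1c(N)c(C(N)=O)c2c(N)ncnc21`). Compound 1 reads > 100000 nM as a limit of the assay. Compound 2 reads > 100000 nM as a limit too. Compound 3 reads > 100000 nM as a limit as well, so it stands without a number. The set as a whole shows the same picture (the limit of > 100000 nM in this assay, at which 3 of the 3 values shown sit).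

The change to compound 4 (`COCCOCn1c(N)c(C(N)=O)c2c(N)ncnc21`) is methoxy in place of hydrogen on a saturated chain carbon, two bonds along the chain from an oxygen on a saturated carbon and reads as ethyl to 2-methoxyethyl. For the measured compounds named here, the one measured step on this chain is a step that the two limits leave unreadable from compound 2 to compound 3 and offers no size to carry over. The expectation therefore rests only on compound 3 at > 100000 nM as a limit. The expected step is a number no higher from compound 3 to compound 4 (the limit leaves the size open) in this assay with no shift beyond the scatter anticipated in either direction. Compound 4 is estimated at 100000 nM with an expected range of 40000 nM to 250000 nM and will most likely be reported only as a limit.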

Compound 4, half-maximal inhibitory concentration: > 100000 nM
Compound 4: no number, only a limit (the forecaster's own chance of this, stated with the estimate: 85%); the middle value lies on the limit itself.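

Compound 2, compound 3 and compound 4 all stand only as limits in this assay, so no step among them can be read: the limit of > 100000 nM in this assay, at which 4 of the 4 values shown sit.

The compounds shown leave open whether any change to this chain on the shared core gives a readable inhibition value.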